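Cytotoxicity notes: methoxycarbonyl analogue of compound 3

The source may hold more compounds than are shown below. What is called first, only, known or untested is meant among the compounds shown, and "the series" means these compounds.

The series shares one core, seen in compound 1 `CCOC(=O)c1ccc(NC(=O)CSc2snnc2-c2ccccc2)c(Br)c1`, compound 2 `Cc1ccc(NC(=O)CSc2snnc2-c2ccccc2)c(Br)c1`, compound 3 `O=C(CSc1snnc1-c1ccccc1)Nc1ccccc1Br` and the unmeasured compound 4 `COC(=O)c1ccc(NC(=O)CSc2snnc2-c2ccccc2)c(Br)c1`. In an ADME assay on MT4 cells (Homo sapiens) for cytotoxicity (a lower number here means that less compound is tolerated, a higher number that more compound is tolerated), compound 1 gives >= 232000 nM, which is a limit of the assay and not a number. In this assay compound 2 likewise reaches only a limit, > 297000 nM. In this assay compound 3 also reaches only a limit, > 307000 nM. Compound 3 therefore cannot be placed relative to the others: all three measured compounds sit at limits, as the limit of > 297000 nM in this assay, at which 1 of the 3 values shown sits, the limit of > 307000 nM in this assay, at which 1 of the 3 values shown sits, and the limit of >= 232000 nM in this assay, at which 1 of the 3 values shown sits, record, so the steps a step that the two limits leave unreadable from compound 1 to compound 2, a step that the two limits leave unreadable from compound 1 to compound 3 and a step that the two limits leave unreadable from compound 2 to compound 3 have no readable size.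

Compound 4 differs from compound 3 by methoxycarbonyl in place of hydrogen on an aromatic carbon. The step that bears most directly on it is a step that the two limits leave unreadable from compound 1 to compound 3, the removal of the related ethoxycarbonyl group, with size unreadable. For the measured compounds named here, no step read beyond the scatter, and compound 1, carrying the ethoxycarbonyl group, gave only the limit >= 232000 nM. The expected step of an at least 1.2-fold lower number from compound 3 to compound 4 (0.08 log units; that floor lies within the scatter) is therefore none beyond the scatter. Compound 4 is expected to give about 250000 nM in this assay, within 100000 nM to 450000 nM, most likely again reported as a limit.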

Compound 4, half-maximal cytotoxic concentration: > 269000 nM
Compound 4: only a limit was reported; the forecaster's own chance of this, stated with the estimate: 85%; middle value at least 1.0-fold (0.03 log units) away from the limit.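

In this assay compound 4 gives > 269000 nM, which is a limit of the assay and not a number. For the compounds shown here, no step between compound 4 and compound 1, compound 2 or compound 3 can be read, as all four values are limits. Open remains whether methoxycarbonyl, ethoxycarbonyl, methyl or hydrogen on this aromatic carbon shifts the cytotoxic concentration at all.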